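Swapping the alkyne-linked ring: from pyridin-4-yl to cyclopentyl

The source may report more compounds than this note shows. Statements on the series, on what has been measured and on what is new or still open speak of the compounds shown alone.

Measured compounds:
- compound 1, `C[C@@H](NC(=O)c1ccc(C#Cc2ccc(F)cc2)cn1)C(C)(C)O`: 38.4%
- compound 2, `C[C@@H](NC(=O)c1ccc(C#Cc2ccc(F)cc2F)cn1)C(C)(C)O`: 38.2%
- compound 3, `C[C@@H](NC(=O)c1ccc(C#Cc2ccncc2)cn1)C(C)(C)O`: 22.4%

All three share one core and differ only in the ring attached to the triple-bonded carbon. In an ADME assay on HEK293 cells for agonist activity at metabotropic glutamate receptor 5 (Rattus norvegicus), read by fluorescence and calcium flux (on this read-out lower numbers stand for smaller maximal responses and higher numbers for larger maximal responses), compound 3 stands lowest of the three. The nearest value is that of compound 2, and a number 15.8 percentage points lower from compound 2 to compound 3 (beyond the scatter); the step of a number 16 percentage points lower from compound 1 to compound 3 (beyond the scatter) is of the same size. Between compound 1 and compound 2 the change is a number 0.2 percentage points lower from compound 1 to compound 2 (within the scatter).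

Compound 4, `C[C@@H](NC(=O)c1ccc(C#CC2CCCC2)cn1)C(C)(C)O`, has not been measured. It differs from compound 3 in one place: cyclopentyl in place of pyridin-4-yl on a triple-bonded carbon. For the measured compounds named here, no measured step exchanges an aromatic ring for a ring of carbon only, so nothing bears on this change directly. What the measured steps show is that placing pyridin-4-yl on the triple-bonded carbon lowered the response in both a number 16 percentage points lower from compound 1 to compound 3 (beyond the scatter) and a number 15.8 percentage points lower from compound 2 to compound 3 (beyond the scatter), so removing it again may allow a partial return, though cyclopentyl is unlike the fluorophenyl rings of compound 1 and compound 2. A small rise is therefore expected, with the estimated step being a number 7.6 percentage points higher from compound 3 to compound 4 (within the scatter), and this expectation carries wide uncertainty. Compound 4 is estimated at 30%, between 14% and 48%.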

Compound 4, largest response reached (reported as efficacy), in percent of the reference or control that the assay uses: 14.8%
Beside the measured number, compound 4's estimate is 15.2 percentage points above it; measured number inside the range.
By their numbers in this assay, from the lowest: compounds 4 and 3 (each within the scatter of the next); then compounds 2 and 1 (each within the scatter of the next).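

In this assay, the change from the aromatic pyridin-4-yl to the non-aromatic, carbon-only cyclopentyl gives a number 7.6 percentage points lower from compound 3 to compound 4 (within the scatter) and so does not separate these two quite different rings on the triple-bonded carbon. The new compound does separate cyclopentyl from the fluorinated phenyl rings, with a number 23.4 percentage points lower from compound 2 to compound 4 (beyond the scatter) and a number 23.6 percentage points lower from compound 1 to compound 4 (beyond the scatter) as the two steps, so compound 1 and compound 2 now stand clear of both lower compounds and not only of the one carrying a ring nitrogen. Nothing else measured on these compounds says why the response differs with the ring at this position.

Open, from the compounds shown here alone, is whether a plain phenyl ring with no fluorine would give a response like that of the fluorinated rings or like that of pyridin-4-yl and cyclopentyl, which would show whether the fluorine matters or the phenyl ring alone is enough. Also open, going by these compounds, is how an open chain such as tert-butyl, a larger carbon ring such as cyclohexyl, or a phenyl ring carrying an amine would behave on the same triple-bonded carbon.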